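The source may report more compounds than this note shows. Statements on the series, on what has been measured and on what is new or still open speak of the compounds shown alone.

Measured so far in a functional assay on A549 cells (Homo sapiens) for antiproliferative activity, read by MTT assay; on this read-out lower numbers stand for stronger inhibition and higher numbers for weaker inhibition:
compound 1 `O=C1N=C(N2CCC[C@H]2C(=O)Nc2ccc3ncnc(Nc4cccc(Cl)c4)c3c2)S/C1=C/c1cccc(Br)n1` gives 3100 nM.
compound 2 `COc1ccccc1/C=C1/SC(N2CCC[C@H]2C(=O)Nc2ccc3ncnc(Nc4cccc(Cl)c4)c3c2)=NC1=O` returns only a limit, > 50000 nM.
compound 3 `O=C1N=C(N2CCC[C@H]2C(=O)Nc2ccc3ncnc(Nc4cccc(Cl)c4)c3c2)S/C1=C/c1ccccc1Br` returns only a limit, > 50000 nM.

Compound 2 thus stands at the limit of this assay, the limit at which two of the three values sit (the limit of > 50000 nM in this assay, at which 2 of the 3 values shown sit); only compound 1 carries a number. The two measured steps that change the group on the double-bonded chain carbon are an at least 16-fold higher number from compound 1 to compound 2 (1.20 log units; beyond the scatter) and an at least 16-fold higher number from compound 1 to compound 3 (1.20 log units; beyond the scatter). Both exchange the 6-bromopyridin-2-yl for a phenyl with a single substituent and both carry the number out of the measurable range. The remaining pair gives a step that the two limits leave unreadable from compound 2 to compound 3.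

Compound 4 `O=C1N=C(N2CCC[C@H]2C(=O)Nc2ccc3ncnc(Nc4cccc(Cl)c4)c3c2)S/C1=C/c1cccnc1Cl` differs from compound 2 by 2-chloropyridin-3-yl in place of 2-methoxyphenyl on a double-bonded chain carbon bound to a double-bonded ring carbon. The new group brings back a pyridine, as in compound 1, while keeping a single halogen on the ring, as in compound 3. Among the compounds with values here, since the starting value is a limit, no measured step from compound 2 can be read in size and the expectation rests on the return to a pyridine. Compound 4 is expected to give about 25000 nM, within 5000 nM to 60000 nM, with a fair chance that this assay again reports only its limit. The expected step is an at least 2.0-fold lower number from compound 2 to compound 4 (0.30 log units; that floor lies within the scatter).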

Compound 4, half-maximal inhibitory concentration: 10800 nM
For compound 4 the middle estimate is 2.3-fold (0.36 log units) above the measured one; the measured number falls inside the stated range.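

In this assay, a pyridine other than 6-bromopyridin-2-yl on the double-bonded chain carbon also yields a measurable number, with an at least 4.6-fold lower number from compound 2 to compound 4 (0.66 log units; beyond the scatter) and an at least 4.6-fold lower number from compound 3 to compound 4 (0.66 log units; beyond the scatter). Within the data shown here, these steps are floors, and they show that the 6-bromopyridin-2-yl of compound 1 is not the only group at this position to give a number. The change from one pyridine to the other still costs something, with a 3.5-fold higher number from compound 1 to compound 4 (0.54 log units; beyond the scatter); across the four compounds shown, the two pyridines carry numbers and the two substituted phenyls do not, with no compound against that pattern, while the step between compound 2 and compound 3 cannot be read, both of them being limits: the limit of > 50000 nM in this assay, at which 2 of the 4 values shown sit.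

Compound 1 and compound 4 differ in the halogen, its place and the place of the ring nitrogen at once, so the compounds shown leave open which of these accounts for the step between them. A 6-chloropyridin-2-yl would separate the halogen from the ring arrangement, and a plain pyridin-3-yl or a 2-aminopyridin-3-yl would show whether a halogen on the pyridine is needed at all.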